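A few compounds are considered here, and "the series" means these few. Any claim that something is new, unique, unknown or untested is made for them only; others in the source may bear on it.

Measured so far in a functional assay on MDA-MB-231 cells (Homo sapiens) for inhibition, read by MTT assay, with a stated time of 72 h; on this read-out lower numbers stand for stronger inhibition and higher numbers for weaker inhibition:
- compound 1 `Cc1ccccc1-c1cc(C(=O)N2CCC3(CC2)CC(=O)c2nn(C(C)(C)C)cc2O3)c2ccccc2n1`: > 10000 nM (a limit of the assay, not a number)
- compound 2 `CC(C)(C)n1cc2c(n1)C(=O)CC1(CCN(C(=O)c3cc(-c4ccc(Cl)cc4)nc4ccccc34)CC1)O2`: > 10000 nM (a limit of the assay, not a number)
- compound 3 `CC(C)(C)n1cc2c(n1)C(=O)CC1(CCN(C(=O)c3cc(-c4ccccn4)nc4ccccc34)CC1)O2`: 8100 nM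

Among the compounds with values here, compound 3 gives 8100 nM, the only true number so far. Compounds 1 and 2 rest at the limit of > 10000 nM in this assay, at which 2 of the 3 values shown sit, so compound 3 cannot be firmly ranked against them.

The next compound is compound 4 `CC(C)(C)n1cc2c(n1)C(=O)CC1(CCN(C(=O)c3cc(Cl)nc4ccccc34)CC1)O2`, and the change is chloro in place of pyridin-2-yl on an aromatic carbon. Here chloro stands in place of pyridin-2-yl on the same aromatic carbon at which compounds 1, 2 and 3 differ. Two measured swaps at that carbon bear on this: an at least 1.2-fold lower number from compound 1 to compound 3 (0.09 log units; that floor lies within the scatter) and an at least 1.2-fold lower number from compound 2 to compound 3 (0.09 log units; that floor lies within the scatter). The third swap is a step that the two limits leave unreadable from compound 1 to compound 2. None of them involves chloro, so no step beyond the scatter is firmly expected in this assay, though a result reported only as a limit is quite possible. The expected change is a 1.4-fold higher number from compound 3 to compound 4 (0.13 log units; within the scatter). For compound 4 the estimated value is 11000 nM, expected to fall between 5000 nM and 30000 nM.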

Compound 4, half-maximal inhibitory concentration: 9220 nM
Estimate against measurement, compound 4: 1.2-fold (0.08 log units) above; low and high end bracket the measured number.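

In this assay, setting chloro in place of the pyridin-2-yl ring gives a 1.1-fold higher number from compound 3 to compound 4 (0.06 log units; within the scatter). Compound 4 is the first compound shown with no ring on this carbon, yet it still gives a true number, and that number cannot be told apart from the one for compound 3. The swaps from the 4-chlorophenyl and 2-methylphenyl groups to chloro read as an at least 1.0-fold lower number from compound 2 to compound 4 (0.03 log units; that floor lies within the scatter) and an at least 1.0-fold lower number from compound 1 to compound 4 (0.03 log units; that floor lies within the scatter), so they settle no order, and the values of compounds 1 and 2 are limits, not numbers: the limit of > 10000 nM in this assay, at which 2 of the 4 values shown sit.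

The compounds shown leave open whether any group on this carbon can move the number beyond the scatter. An amine or a morpholine ring at this carbon would put that question to a different kind of group.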